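The compounds below may be only part of what the source reports. "The series", "measured", "known", "first", "only" and "open" are said of these compounds alone.

Among the compounds with values here, in a functional assay on MDA-MB-231 cells (Homo sapiens) for antiproliferative activity, read by WST assay, with a stated time of 72 h (a higher number here means a weaker inhibitor, a lower number a stronger inhibitor), compound 1 `CCN(CC)CC#CCSc1nc2c(c(=O)[nH]c(=O)n2C)n1C` gives 68100 nM, the highest of the three numbers so far. Compound 3 `Cn1cnc2nc(SCC#CCN3CCCC3)nc(SCC#CCN3CCCC3)c21` gives 20000 nM, and compound 2 `Cn1cnc2nc(SCC#CCN3CCCCC3)nc(SCC#CCN3CCCCC3)c21` gives 7350 nM. Within the data shown here, both differ from compound 1 in more than one place, and no single-change step has been measured. Compound 4 `Cn1c(SCC#CCN2CCCCC2)nc2c1c(=O)[nH]c(=O)n2C` has piperidin-1-yl in place of diethylamino on a saturated chain carbon bound to a triple-bonded carbon. A modest move to a lower number, near the edge of the scatter, is expected because compound 2, which also carries piperidin-1-yl, reads 7350 nM. The estimated change is a 1.9-fold lower number from compound 1 to compound 4 (0.29 log units; within the scatter). For compound 4 the estimated value is 35000 nM, with an expected range of 14000 nM to 80000 nM.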

Compound 4, half-maximal inhibitory concentration: 364000 nM
For compound 4 the middle estimate is 10-fold (1.02 log units) below the measured one, outside the stated range (above it).
By their numbers in this assay, from the lowest: compound 2; then compound 3; then compound 1; then compound 4.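

In this assay, replacing diethylamino with piperidin-1-yl on a saturated chain carbon bound to a triple-bonded carbon gives a 5.3-fold higher number from compound 1 to compound 4 (0.73 log units; beyond the scatter). Within the data shown here, this is the first single-change step, and it shows that the identity of the amine at this place alters the reading on the core of compound 1. Nothing available accounts for this step. Still open, from the compounds shown here alone, is how dimethylamino or morpholin-4-yl would read at the same place on this core. Going by these compounds, whether the step carries over to another core also remains open.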